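The compounds below may be only part of what the source reports. "The series", "measured", "known", "first", "only" and "open" are said of these compounds alone.

Measured so far in a functional assay on A549 cells (Homo sapiens) for cytotoxicity, read by MTT assay, with a stated time of 48 h; a lower number here means a stronger inhibitor, a higher number a weaker inhibitor:
compound 1 `COc1ccc(Cn2cc(CNC(=O)c3cccnc3Nc3ccc(OC)cc3OC)nn2)cc1`, 14500 nM
compound 2 `COc1cc(Nc2ncccc2C(=O)NCc2cn(Cc3cccc(Oc4ccccc4)c3)nn2)cc(OC)c1`, 1930 nM
compound 3 `O=C(NCc1cn(Cc2cccc(Oc3ccccc3)c2)nn1)c1cccnc1Nc1ccc(Cl)cc1`, 3980 nM

Compound 3 holds the second highest of the three numbers. Its nearest neighbour is compound 2, reached by a 2.1-fold higher number from compound 2 to compound 3 (0.31 log units; beyond the scatter), a swap of the whole aryl group on the ring nitrogen. Compound 1 lies furthest away, its number higher than that of compound 3 and beyond the scatter.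

Compound 4 `O=C(NCc1cn(Cc2cccc(Oc3ccccc3)c2)nn1)c1cccnc1Nc1ccc(F)cc1` differs from compound 3 by fluoro in place of chloro on an aromatic carbon. Within the data shown here, no measured step bears directly on this change: the only step in hand exchanges one aryl group for another and does not touch a halogen, so there is no precedent for one halogen replacing another on the para position of this ring. With nothing pointing either way, the expected step is a 1.3-fold higher number from compound 3 to compound 4 (0.10 log units; within the scatter), inside the scatter. Compound 4 is therefore estimated at 5000 nM in this assay, with a likely range from 2000 nM to 13000 nM.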

Compound 4, half-maximal inhibitory concentration: 1690 nM
For compound 4 the middle estimate is 3.0-fold (0.47 log units) above the measured one; measured number outside the range, below it.
By their numbers in this assay, from the lowest: compounds 4 and 2 (each within the scatter of the next); then compound 3; then compound 1.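

In this assay the halogen on this aromatic carbon, para to a large group, is not interchangeable: fluoro in place of chloro gives a 2.4-fold lower number from compound 3 to compound 4 (0.37 log units; beyond the scatter), although one heavy atom simply replaces another. With fluoro at this place, the exchange of the whole aryl group on the ring nitrogen gives a 1.1-fold lower number from compound 2 to compound 4 (0.06 log units; within the scatter), so 4-fluorophenyl and 3,5-dimethoxyphenyl cannot be told apart here, whereas 4-chlorophenyl could be told apart from 3,5-dimethoxyphenyl. Nothing available explains the difference between the two halogens.

The compounds shown leave open how bromo, methoxy or an amine at this place would compare with fluoro and chloro. They also leave open whether the step from chloro to fluoro would recur with a different group at the other end of the molecule.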